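A few compounds are considered here, and "the series" means these few. Any claim that something is new, unique, unknown or untested is made for them only; others in the source may bear on it.

Compound 2 `Cc1cc(C(=O)N[C@H]2CCN(Cc3ccc(OCCCN(C)C)cc3)C2)ccc1Br` is one of two compounds with a number in an assay on HEK293 cells for binding affinity to Urotensin-2 receptor (Homo sapiens), read by radioligand binding (on this read-out lower numbers stand for stronger inhibition and higher numbers for weaker inhibition), where compound 2 gives 631 nM. Compound 1 `Cc1cc(C(=O)N[C@H]2CCN(Cc3ccc(OCCCN(C)C)cc3)C2)ccc1Cl` gives 631 nM in this assay, and the step of no change at the digits printed from compound 1 to compound 2 (within the scatter) was no more than scatter. Compound 3 `CN(C)CCCOc1ccc(CN2CC[C@H](NC(=O)c3ccc(C(F)(F)F)cc3)C2)cc1` returns only a limit in this assay, < 10000 nM, so that the limit of < 10000 nM in this assay, at which 1 of the 3 values shown sits, caps what can be read. The steps a step that the limit leaves unreadable from compound 1 to compound 3 and a step that the limit leaves unreadable from compound 2 to compound 3 therefore have no readable size. Compound 4 `CN(C)CCCOc1ccc(CN2CC[C@H](NC(=O)c3ccncc3)C2)cc1` carries the change (pyridin-4-yl in place of 4-bromo-3-methylphenyl on a carbonyl carbon). Among the measured compounds shown here, only the step to compound 3 bears on this, and it shows a substituted phenyl exchanged for another group meeting the limit; a weakening is expected, a 7.9-fold higher number from compound 2 to compound 4 (0.90 log units; beyond the scatter). Compound 4 is estimated at 5000 nM, between 1500 nM and 20000 nM.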

Compound 4, inhibition constant: < 10000 nM
Compound 4 was reported as a limit; the forecaster's own chance of this, stated with the estimate: 50%; the middle value is on the limit's open side.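

Compound 4 also returns only a limit, so none of the steps from compound 1, compound 2 or compound 3 to compound 4 can be read: the limit of < 10000 nM in this assay, at which 2 of the 4 values shown sit.

The compounds shown leave open how compound 3 and compound 4 actually compare with compound 1 and compound 2, or with each other.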